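This account rests on a few compounds, and the source may have more. Where it says the series, first, only, none or still open, it means among the compounds named here.

Measured so far:
- compound 1, `CCOC(=O)N(C)C(C)C#CCN1CCCC1`, 97 mg/kg
- compound 2, `CCOC(=O)N(C)C(C)C#CCn1ccnc1`, 54 mg/kg
- compound 3, `CC(C#CCN1CCCC1)N1CCN(C)C1=O`, 4.5 mg/kg

All three were tested in a functional assay on the whole organism for antagonist activity, with Mus musculus as the target; a lower number here means that less compound is needed, a higher number that more compound is needed for the effect. Compound 1 and compound 2 share a core and differ in one place: 1H-imidazol-1-yl in place of pyrrolidin-1-yl on a saturated chain carbon bound to a triple-bonded carbon. The step between them, a 1.8-fold lower number from compound 1 to compound 2 (0.25 log units; within the scatter), is small enough to sit within the usual scatter of repeated measurements, so the two values cannot be ranked against each other. Compound 3 has a different core; how it differs from the core of compound 1 is not broken down here. In this assay compound 3 gives the lowest of the three numbers, and its distance to both compound 1 and compound 2 lies beyond the scatter.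

Compound 4, `CC(C#CCn1ccnc1)N1CCN(C)C1=O`, has not yet been measured. It is built on the core of compound 3 and differs from compound 3 in one place: 1H-imidazol-1-yl in place of pyrrolidin-1-yl on a saturated chain carbon bound to a triple-bonded carbon. For the measured compounds named here, this is the same change as the one from compound 1 to compound 2, made at the same kind of position. Since that earlier step was a 1.8-fold lower number from compound 1 to compound 2 (0.25 log units; within the scatter) and stayed within the scatter, the step from compound 3 to compound 4 is expected to be of similar modest size, a 1.3-fold lower number from compound 3 to compound 4 (0.11 log units; within the scatter). Resting on this one prior example only, compound 4 is estimated to give 3.5 mg/kg in this assay, with a plausible range from 1.2 mg/kg to 10 mg/kg.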

Compound 4, dose for half-maximal effect: 21 mg/kg
Estimate against measurement, compound 4: 6.0-fold (0.78 log units) below; measured number above the stated range.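

On the core of compound 3, the swap of pyrrolidin-1-yl for 1H-imidazol-1-yl on a saturated chain carbon bound to a triple-bonded carbon has a clear cost in this assay: there is a 4.7-fold higher number from compound 3 to compound 4 (0.67 log units; beyond the scatter), so more compound is needed for the effect once the imidazole is in place. The change therefore does not carry over from one core to the other as a fixed step, and the two results differ by more than measurement scatter can account for: the same change on two cores in this assay, a 1.8-fold lower number (0.25 log units; within the scatter) from compound 1 to compound 2 and a 4.7-fold higher number (0.67 log units; beyond the scatter) from compound 3 to compound 4, 8.4-fold (0.92 log units) apart, beyond the scatter of two such steps. For the compounds shown here, this shows that the effect of the swap depends on the core in this small set, but with only two pairs it does not show which feature of the cores is responsible or how the swap would behave on a third core.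

The compounds shown leave open how other groups at this place, such as a piperidine ring or a dimethylamino group, would compare with pyrrolidin-1-yl and 1H-imidazol-1-yl on each core. They also leave open whether the sensitivity seen on the core of compound 3 is specific to the imidazole or would appear with other replacements for pyrrolidin-1-yl.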